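The source may report more compounds than this note shows. Statements on the series, on what has been measured and on what is new or still open speak of the compounds shown alone.

Compound 1, `CN(C)c1ccc2cc(-c3ccccc3Cl)c(N)nc2c1`, is the reference point of this small series. In a toxicity assay on J774.A1 cells (Mus musculus) for cytotoxicity, read by SYBR Green assay, with a stated time of 1 h (a higher number here means that more compound is needed for the effect, a lower number that less compound is needed), compound 1 gives 2400 nM, the lowest number among the three compounds that have been measured. Its two neighbours each carry one additional chloro substituent on the pendant ring: compound 2, `CN(C)c1ccc2cc(-c3cccc(Cl)c3Cl)c(N)nc2c1`, gives 4900 nM in this assay, and compound 3, `CN(C)c1ccc2cc(-c3cc(Cl)ccc3Cl)c(N)nc2c1`, gives 9800 nM. Both steps away from compound 1 move upward, a 2.0-fold higher number from compound 1 to compound 2 (0.31 log units; beyond the scatter) and a 4.1-fold higher number from compound 1 to compound 3 (0.61 log units; beyond the scatter), so adding a chloro to the pendant ring has so far raised the number each time.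

Compound 4, `CN(C)c1ccc2cc(-c3ncccc3F)c(N)nc2c1`, takes a different route. The change from compound 1 is 3-fluoropyridin-2-yl in place of 2-chlorophenyl on an aromatic carbon. Among the compounds with values here, no measured step swaps the whole pendant ring for a heteroaromatic one, so the chloro additions bear on compound 4 only indirectly: they show that the pendant ring tolerates modification without a large drop, and that the measured moves have been modest and upward. Because the two measured steps, a 2.0-fold higher number from compound 1 to compound 2 (0.31 log units; beyond the scatter) and a 4.1-fold higher number from compound 1 to compound 3 (0.61 log units; beyond the scatter), were both modest, a step of similar or smaller size is expected for compound 4 in this assay, with a 1.5-fold higher number from compound 1 to compound 4 (0.16 log units; within the scatter) as the estimated change. Compound 4 is therefore expected to give about 3500 nM in this assay, within a range of 1200 nM to 10000 nM.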

Compound 4, half-maximal effective concentration: 16000 nM
Estimate against measurement, compound 4: 4.6-fold (0.66 log units) below, outside the stated range (above it).
By their numbers in this assay, from the lowest: compound 1; then compounds 2, 3 and 4 (each within the scatter of the next, the first and the last beyond it).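

At this position on the shared core, exchanging the whole pendant ring gives a 6.7-fold higher number from compound 1 to compound 4 (0.82 log units; beyond the scatter) in this assay, so the number can rise without any added chloro, and even with the chlorine of compound 1 gone. The rise also comes with no change in the heavy-atom count of the group, since 2-chlorophenyl and 3-fluoropyridin-2-yl are the same size by that count, although the entering group brings a ring nitrogen counted as a hydrogen-bond acceptor and a fluorine in place of the chlorine. Nothing available explains why this exchange raises the number.

The step from compound 1 to compound 4 changes the ring atoms and the halogen together, so the compounds shown leave open how much of the rise belongs to the ring nitrogen and how much to the fluorine, a question that 2-fluorophenyl or unsubstituted pyridin-2-yl at this position would separate. They also leave open whether a pendant ring carrying an amine or a carboxylic acid, or a saturated ring such as morpholine, would move the number in the same upward direction.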